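Swapping iodo for fluoro on the aryl ring of compound 2

The source may hold more compounds than are shown below. What is called first, only, known or untested is meant among the compounds shown, and "the series" means these compounds.

Measured so far:
compound 1 `COc1cccc(-c2ccc([C@H]3S[C@@H](C)C(=O)Nc4c3c(C)nn4-c3ccccc3C)cc2)c1`: 41%
compound 2 `Cc1nn(-c2ccccc2I)c2c1C(c1ccc(Oc3ccccc3)cc1)SC(C)C(=O)N2`: 130%

The two measured compounds were tested in an assay on isolated protein for agonist activity at Bile acid receptor (Homo sapiens), read by AlphaScreen, with a stated time of 30 min; a higher number here means a larger maximal response, a lower number a smaller maximal response. Compound 1 `COc1cccc(-c2ccc([C@H]3S[C@@H](C)C(=O)Nc4c3c(C)nn4-c3ccccc3C)cc2)c1` gives 41% in this assay. Compound 2 `Cc1nn(-c2ccccc2I)c2c1C(c1ccc(Oc3ccccc3)cc1)SC(C)C(=O)N2` gives 130% in the same measurement. Going by the values given here, compound 2 thus stands highest of the two numbers, and the gap to compound 1, its only neighbour, lies well beyond the scatter of this kind of measurement. Among the compounds with values here, no pair of compounds differing in a single place has been measured, so there is no directly comparable step to lean on.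

Compound 3 `Cc1nn(-c2ccccc2F)c2c1C(c1ccc(Oc3ccccc3)cc1)SC(C)C(=O)N2` has not yet been measured. Its difference from compound 2 is a single exchange: fluoro in place of iodo on an aromatic carbon. Without a measured precedent for this kind of exchange, the expectation for the step from compound 2 to compound 3 in this assay is a modest fall, a number 30 percentage points lower from compound 2 to compound 3 (beyond the scatter), which may or may not exceed the scatter. For compound 3 the estimated value in this assay is 100%, with a range from 50% to 140%.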

Compound 3, largest response reached (reported as efficacy), in percent of the reference or control that the assay uses: 72%
Compound 3: middle estimate off by 28 percentage points, on the high side; measured number inside the range.
By their numbers in this assay, from the lowest: compound 1; then compound 3; then compound 2.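

In this assay, going by these compounds alone, putting fluoro in place of iodo on this aromatic carbon, ortho to a large group, gives a number 58 percentage points lower from compound 2 to compound 3 (beyond the scatter) and provides the first direct comparison of compounds that differ in one place. The change swaps only one heavy atom for another, with no ring, hydrogen-bond donor, hydrogen-bond acceptor or net charge entering or leaving, yet the maximal response still shifts clearly, so this position on the aryl ring matters for the read-out and the choice of halogen there is not interchangeable. Nothing at hand explains why the iodo compound reaches the larger response, and the numbers record the size of the shift without giving its cause.

As far as these compounds go, with only iodo and fluoro compared on this scaffold, it remains open whether chloro or bromo at the same place would fall between compound 2 and compound 3 or outside that span. From the compounds shown here alone, it is equally open whether a group that is not a halogen, such as trifluoromethyl or methoxy, could keep the higher response, and whether the same exchange would have a similar effect in a compound with a different remainder.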